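Methyl on the Amine Carbon: Expecting a Flat Step

This account rests on a few compounds, and the source may have more. Where it says the series, first, only, none or still open, it means among the compounds named here.

Three compounds share one core and differ only in the chain and its attached groups. Compound 1 `COc1cc2sn(CCCCN(C)Cc3ccccc3)c(=O)c2cc1OC` gives 19700 nM in an assay on isolated protein for inhibition of Amine oxidase [flavin-containing] B (Homo sapiens), read by fluorescence, with a stated time of 30 min; a higher number here means a weaker inhibitor, a lower number a stronger inhibitor. Compound 2 `CCN(CCCCn1sc2cc(OC)c(OC)cc2c1=O)Cc1ccccc1` gives 20100 nM, and compound 3 `COc1ccccc1CN(C)CCCCn1sc2cc(OC)c(OC)cc2c1=O` gives 19200 nM. Compound 3 shows the lowest of the three numbers, yet its distance to compound 1 and to compound 2 lies within the scatter of repeated measurements, so no order among the three can be claimed.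

Compound 4 `CCN(CCCCn1sc2cc(OC)c(OC)cc2c1=O)Cc1ccccc1OC` has not yet been measured. It differs from compound 3 by methyl in place of hydrogen on a saturated chain carbon bound to an amine nitrogen. The same change has already been seen once: the step of a 1.0-fold higher number from compound 1 to compound 2 (0.01 log units; within the scatter), which did not move the number beyond the scatter. That step bears directly on the new one, since the only other difference, the methoxy on the aromatic carbon, also gave a flat step in a 1.0-fold lower number from compound 1 to compound 3 (0.01 log units; within the scatter).

On this basis the step of a 1.0-fold higher number from compound 3 to compound 4 (0.01 log units; within the scatter) is expected to stay within the scatter. Compound 4 is therefore estimated at 19500 nM in this assay, with a range from 10000 nM to 39000 nM.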

Compound 4, half-maximal inhibitory concentration: 19400 nM
Estimate against measurement, compound 4: 1.0-fold (0.00 log units) above; the measured number falls inside the stated range.
By their numbers in this assay, from the lowest: compounds 3, 4, 1 and 2 (each within the scatter of the next).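

The methyl-to-ethyl change, with a methyl placed on a saturated chain carbon bound to an amine nitrogen, now has a second reading in this assay: it gives a 1.0-fold higher number from compound 3 to compound 4 (0.00 log units; within the scatter). This shows that the flat result at this position also holds when the methoxy is present, and the two readings agree: the same change on two cores in this assay, a 1.0-fold higher number (0.01 log units; within the scatter) from compound 1 to compound 2 and a 1.0-fold higher number (0.00 log units; within the scatter) from compound 3 to compound 4, 1.0-fold (0.00 log units) apart, within the scatter of two such steps The methoxy on the aromatic carbon, now read with the ethyl in place, gives a 1.0-fold lower number from compound 2 to compound 4 (0.02 log units; within the scatter), so the two changes can be combined with no step beyond the scatter, and this change also repeats: the same change on two cores in this assay, a 1.0-fold lower number (0.01 log units; within the scatter) from compound 1 to compound 3 and a 1.0-fold lower number (0.02 log units; within the scatter) from compound 2 to compound 4, 1.0-fold (0.00 log units) apart, within the scatter of two such steps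

These compounds leave open whether a larger group at this position, such as a propyl or a benzyl in place of the ethyl, or a carboxylic acid in place of the methoxy, would move the number at all. Since every step here is flat, they also leave open which part of these molecules governs the number, including whether a shorter or longer chain linking the shared core to the amine nitrogen would shift it.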